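The compounds below may be only part of what the source reports. "The series", "measured", "known", "first", "only" and "open" are said of these compounds alone.

The measurements come from an ADME assay for permeability, using PAMPA, with a stated time of 30 min, at pH 7.4 (a lower number here means that the compound crosses the layer more slowly, a higher number that the compound crosses the layer faster), and cover three compounds:

Compound 1, `COc1cccc(CNCCCNc2ccnc3cc(Oc4ccccc4)ccc23)c1O`, gives 317 10^-6 cm/s.
Compound 2, `CC(C)(C)c1ccc(Oc2ccc3c(NCCCNCc4ccco4)ccnc3c2)cc1`, gives 317 10^-6 cm/s.
Compound 3, `Cc1cc(C)cc(Cc2ccc3c(NCCCNCc4ccco4)ccnc3c2)c1`, gives 23 10^-6 cm/s.

Compound 1 and compound 2 stand level at the digits printed, and together they hold the highest number of the three. Compound 3 sits well apart from both, with a lower number than that of compound 1, a gap that lies beyond the scatter. No pair of these compounds differs in a single place, so no step between measured compounds can be drawn.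

The compound still to be measured is compound 4, `COc1cccc(CNCCCNc2ccnc3cc(-c4ccc(F)cc4)ccc23)c1O`. It differs from compound 1 in one place: 4-fluorophenyl in place of phenoxy on an aromatic carbon. Within the data shown here, nothing among the measured compounds isolates such a swap, so the expectation rests on compound 1 alone. In this assay compound 4 is expected to land close to compound 1, the step of a 1.1-fold lower number from compound 1 to compound 4 (0.05 log units; within the scatter) being estimated as none beyond the scatter. The estimate for compound 4 is therefore 280 10^-6 cm/s, within a range from 120 10^-6 cm/s to 500 10^-6 cm/s.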

Compound 4, apparent permeability: 237 10^-6 cm/s
Compound 4: the middle estimate sits 1.2-fold (0.07 log units) above what was measured, within the range that was stated.
By their numbers in this assay, from the lowest: compound 3; then compounds 4, 1 and 2 (each within the scatter of the next).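

In this assay, 4-fluorophenyl in place of phenoxy on this aromatic carbon gives a 1.3-fold lower number from compound 1 to compound 4 (0.13 log units; within the scatter), so this single change leaves the read-out within the scatter. The earlier compounds shown here held no such step; this one shows that at this position, a ring attached directly and carrying fluorine can stand in for phenoxy, with the same count of heavy atoms but one hydrogen-bond acceptor fewer, without a change beyond the scatter. No measurement shown gives a reason for this result.

The swap changes the oxygen link and adds the fluorine together, and the compounds shown do not separate these two parts. From the compounds shown here alone, whether this position would tolerate a basic amine such as piperazine, a carboxylic acid or a longer chain also remains open.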